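This account rests on a few compounds, and the source may have more. Where it says the series, first, only, none or still open, it means among the compounds named here.

Measured in a toxicity assay on cells (Macrophage, Mus musculus, strain BALB/c) for cytotoxicity, read by MTT assay; a higher number here means a weaker inhibitor, a lower number a stronger inhibitor:
- compound 1 `COc1cc(O)cc(O)c1C(=O)/C=C/c1ccco1`: 384000 nM
- compound 2 `COc1cc(O)cc(O)c1C(=O)/C=C/c1ccc(Cl)cc1`: 19000 nM
- compound 3 `COc1cc(O)cc(O)c1C(=O)/C=C/c1ccccc1F`: 16000 nM

Compound 3 stands at the low end of these values, at 16000 nM. It cannot be ranked against its nearest neighbour, since the data show a 1.2-fold lower number from compound 2 to compound 3 (0.07 log units; within the scatter). The gap to the far end is much wider, with a 24-fold lower number from compound 1 to compound 3 (1.38 log units; beyond the scatter).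

The next compound is compound 4 `COc1cc(O)cc(O)c1C(=O)/C=C/Cc1ccccc1`, which carries benzyl in place of 2-fluorophenyl on a double-bonded chain carbon bound to a double-bonded chain carbon.

Within the data shown here, three measured steps bear on this change. The large ones, a 20-fold lower number from compound 1 to compound 2 (1.31 log units; beyond the scatter) and a 24-fold lower number from compound 1 to compound 3 (1.38 log units; beyond the scatter), both replace furan-2-yl with a group holding a six-membered aromatic ring of carbon only. Exchanging one such group for another gave only a 1.2-fold lower number from compound 2 to compound 3 (0.07 log units; within the scatter). Benzyl also holds that ring, so no large step is expected in this assay, although no measured compound tests benzyl itself. Among the measured compounds shown here, the one distant value, compound 1 at 384000 nM, is higher, so the estimate leans slightly upward. The expected change is a 1.8-fold higher number from compound 3 to compound 4 (0.24 log units; within the scatter). Compound 4 is estimated at 28000 nM, with an expected range from 10000 nM to 120000 nM.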

Compound 4, half-maximal inhibitory concentration: 27000 nM
Beside the measured number, compound 4's estimate is 1.0-fold (0.02 log units) above it; the range from low to high includes it.
By their numbers in this assay, from the lowest: compounds 3, 2 and 4 (each within the scatter of the next); then compound 1.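

In this assay, benzyl in place of 2-fluorophenyl gives a 1.7-fold higher number from compound 3 to compound 4 (0.23 log units; within the scatter), and benzyl in place of 4-chlorophenyl gives a 1.4-fold higher number from compound 2 to compound 4 (0.15 log units; within the scatter), so at this position, on a double-bonded chain carbon bound to a double-bonded chain carbon, a group made only of carbon cannot be told apart from the two halogen-bearing groups. The contrast with furan-2-yl remains, with a 14-fold lower number from compound 1 to compound 4 (1.15 log units; beyond the scatter), so all three groups holding a six-membered aromatic ring of carbon only now stand apart from furan-2-yl, while compounds 2, 3 and 4 cannot be ranked among themselves. Nothing available explains why these groups behave alike or why furan-2-yl stands apart.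

Going by these compounds, it remains open whether the six-membered aromatic ring itself is what separates these compounds from compound 1, since a pyridine ring or an open hexyl chain at this position could fall on either side of that gap. On these data alone, it is equally open whether an amine or a carboxylic acid on the benzyl ring would leave the number in this assay where it stands.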